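From a ring to an open chain on the shared core

This account rests on a few compounds, and the source may have more. Where it says the series, first, only, none or still open, it means among the compounds named here.

Three compounds share one core and differ only in the group on a saturated chain carbon bound to an aromatic carbon and a saturated chain carbon. Compound 1 `CC(C)C(c1ncco1)c1ccc(-c2ccc3cccc(F)c3c2)[nH]c1=O` gives 24 nM in an assay on CHO cells for displacement of a labelled ligand from prostaglandin E2 receptor EP3 subtype (Homo sapiens), read by radioligand binding; on this read-out lower numbers stand for stronger inhibition and higher numbers for weaker inhibition. Compound 2 `CC(C)C(c1noc(=O)[nH]1)c1ccc(-c2ccc3cccc(F)c3c2)[nH]c1=O` gives 15 nM in this assay, and compound 3 `CC(C)C(/C=C1/CCNC1=O)c1ccc(-c2ccc3cccc(F)c3c2)[nH]c1=O` gives 5.3 nM in this assay. Compound 3 stands lowest of the three: the steps of a 4.5-fold lower number from compound 1 to compound 3 (0.66 log units; beyond the scatter) and a 2.8-fold lower number from compound 2 to compound 3 (0.45 log units; beyond the scatter) both lie beyond the scatter, while a 1.6-fold lower number from compound 1 to compound 2 (0.20 log units; within the scatter) does not.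

Compound 4 `CC(C)NC(=O)CC(c1ccc(-c2ccc3cccc(F)c3c2)[nH]c1=O)C(C)C` is compound 3 with one change: a group of 7 heavy atoms (5 carbon, 1 nitrogen, 1 oxygen; no ring) in place of a group of 7 heavy atoms (5 carbon, 1 nitrogen, 1 oxygen; one five-membered non-aromatic ring with 1 hetero atom), on a saturated chain carbon bound to an aromatic carbon and a saturated chain carbon. Going by the values given here, no measured step covers this kind of change, since the three measured steps all exchange one ring for another, and the two that reach compound 3 show that this ring gave a lower number than either aromatic ring before it. Opening the ring into a chain is a departure from the group that did best, so a modest move to a higher number in this assay is expected rather than none. The expected step is a 2.8-fold higher number from compound 3 to compound 4 (0.45 log units; beyond the scatter). For compound 4 the estimate in this assay is 15 nM, with a likely range from 5 nM to 45 nM.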

Compound 4, inhibition constant: 5.8 nM
Compound 4: the middle estimate sits 2.6-fold (0.41 log units) above what was measured; the range from low to high includes it.
By their numbers in this assay, from the lowest: compounds 3 and 4 (each within the scatter of the next); then compounds 2 and 1 (each within the scatter of the next).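

Replacing the five-membered non-aromatic ring with the open (isopropylcarbamoyl)methyl chain gives a 1.1-fold higher number from compound 3 to compound 4 (0.04 log units; within the scatter), so in this assay a ring on this saturated chain carbon is not needed to keep the low number, and the two groups cannot be told apart. The open chain also keeps the advantage over both aromatic rings, with a 2.6-fold lower number from compound 2 to compound 4 (0.41 log units; beyond the scatter) and a 4.1-fold lower number from compound 1 to compound 4 (0.62 log units; beyond the scatter), so among these four groups the two lowest numbers belong to one group with a ring and one without, and the two aromatic rings are the ones that fall behind. Nothing measured here explains this result.

The compounds shown leave open which parts of the (isopropylcarbamoyl)methyl group matter, for instance whether the isopropyl end could give way to a methyl or a cyclopropyl group with no change in the number. As far as these compounds go, they also leave open how a carboxylic acid, an amine or a longer chain would read on the same carbon, so the limits of what this position accepts remain unknown.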